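The source may hold more compounds than are shown below. What is called first, only, known or untested is meant among the compounds shown, and "the series" means these compounds.

Measured in a functional assay on SGC-7901 cells (Homo sapiens) for antiproliferative activity, read by MTT assay, with a stated time of 72 h; on this read-out higher numbers stand for weaker inhibition and lower numbers for stronger inhibition:
- Compound 1 `COc1ccccc1-c1ccc2ncn(-c3cc(OC)c(OC)c(OC)c3)c2c1`: 5050 nM
- Compound 2 `COc1cc(-n2cnc3ccc(-c4ccccc4Cl)cc32)cc(OC)c1OC`: > 10000 nM, a limit of the assay
- Compound 3 `COc1cc(-n2cnc3ccc(-c4ccc(C)cc4F)cc32)cc(OC)c1OC`: 5650 nM

In this assay, compound 3 stands level with compound 1, with a 1.1-fold higher number from compound 1 to compound 3 (0.05 log units; within the scatter). Compound 4 `COc1ccc(-c2ccc3ncn(-c4cc(OC)c(OC)c(OC)c4)c3c2)cc1O` differs from compound 3 at that same aromatic carbon: 3-hydroxy-4-methoxyphenyl in place of 2-fluoro-4-methylphenyl on an aromatic carbon. The steps of an at least 1.9-fold higher number from compound 1 to compound 2 (0.29 log units; that floor lies within the scatter) and an at least 1.7-fold lower number from compound 2 to compound 3 (0.24 log units; that floor lies within the scatter) also change this group, but both rest on the limit of compound 2. For the measured compounds named here, no measured compound carries a 3-hydroxy-4-methoxyphenyl group, so these steps are only a loose guide. Tentatively, the expected change is an 11-fold lower number from compound 3 to compound 4 (1.05 log units; beyond the scatter), towards stronger inhibition and beyond the measured steps. For compound 4 the estimated value is 500 nM, with an expected range of 15 nM to 8000 nM.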

Compound 4, half-maximal inhibitory concentration: 44 nM
Compound 4: middle estimate off by 11-fold (1.06 log units), on the high side; low and high end bracket the measured number.
By their numbers in this assay, from the lowest: compound 4; then compounds 1 and 3 (each within the scatter of the next). At a limit, above all of these: compound 2.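

In this assay, the entry of 3-hydroxy-4-methoxyphenyl gives a 130-fold lower number from compound 3 to compound 4 (2.11 log units; beyond the scatter) and a 110-fold lower number from compound 1 to compound 4 (2.06 log units; beyond the scatter), whereas the earlier step between compound 1 and compound 3 stayed within the scatter. Compound 2 stands at a limit of the assay, so an at least 220-fold lower number from compound 2 to compound 4 (2.35 log units; beyond the scatter) is only a floor: the limit of > 10000 nM in this assay, at which 1 of the 4 values shown sits. This aromatic carbon can therefore carry a large change in inhibition, which compounds 1, 2 and 3 alone did not reveal.

The compounds shown leave open whether the hydroxy or the methoxy of the entering group accounts for the step. They also leave open whether an amine in place of that hydroxy would keep it.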